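The source may hold more compounds than are shown below. What is called first, only, known or untested is meant among the compounds shown, and "the series" means these compounds.

The study concerns three measured compounds and one still to be tested in a functional assay on K562 cells (Homo sapiens) for inhibition, read by MTT assay, with a stated time of 72 h; a lower number here means a stronger inhibitor, a higher number a weaker inhibitor. Compound 1 `CCc1ccc(C(=O)/C=C/C(=O)O)cc1` gives 5530 nM in this assay, the lowest of the three numbers. Compound 2 `O=C(O)/C=C/C(=O)C1CCc2ccccc2C1` gives 5600 nM, which lies within the scatter of the number for compound 1, so the two cannot be told apart. Compound 3 `Cc1ccc(C(=O)/C=C/C(=O)O)c(Cl)c1` gives 14600 nM, a higher number that lies beyond the scatter when set against compound 1. No two of these compounds differ in only one place, so no single step has been measured among them. Compound 4 `CC(C)c1ccc(C(=O)/C=C/C(=O)O)cc1` is the compound not yet measured. It differs from compound 1 by methyl in place of hydrogen on a saturated chain carbon bound to an aromatic carbon and a saturated chain carbon; cut one bond further out, the change reads ethyl to isopropyl. Going by the values given here, nothing among the measured compounds shows what such a change does. For compound 4 the expectation is a step from compound 1 of no more than the scatter, in either direction: a 1.1-fold lower number from compound 1 to compound 4 (0.04 log units; within the scatter). Compound 4 is estimated at 5000 nM, with a range from 2500 nM to 10000 nM.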

Compound 4, half-maximal inhibitory concentration: 5560 nM
The estimate for compound 4 lay 1.1-fold (0.05 log units) below the measured number; measured number inside the range.
By their numbers in this assay, from the lowest: compounds 1, 4 and 2 (each within the scatter of the next); then compound 3.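

In this assay, the change from ethyl to isopropyl gives a 1.0-fold higher number from compound 1 to compound 4 (0.00 log units; within the scatter), the first single step measured among these compounds. Going by these compounds alone, on this saturated chain carbon, then, methyl in place of hydrogen gives a number that cannot be told apart from that of compound 1, something the earlier compounds could not show, as no two of them differed in only one place. Nothing at hand bears on why the two numbers fall so close together. Still open, on these data alone, is whether a tert-butyl group, a cyclopropyl ring, a hydroxyl or an amine at this place would likewise leave the number within the scatter. Also open, as far as these compounds go, is whether the same methyl step would read alike on any other core.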